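The source may report more compounds than this note shows. Statements on the series, on what has been measured and on what is new or still open speak of the compounds shown alone.

Measured compounds:
compound 1 `Cc1ccc(-c2nc(=O)o[nH]2)c(-c2ccc([C@@H](C)N(CC3CC3)c3nc4c(C(=O)O)cccc4o3)cc2)c1` — 0.00023
compound 2 `CCCCN(c1nc2c(C(=O)NC)cccc2o1)[C@H](C)c1ccc(-c2ccccc2-c2nnn[nH]2)cc1` — 0.000975

Working notes on the series. Going by the values given here, in an ADME assay on the whole organism (plasma, Macaca fascicularis) for protein binding, read by LC-MS, using equilibrium dialysis and cassette dosing, with a stated time of 24 h, at a dose of 1 mg/kg by the oral route (on this read-out lower numbers stand for a smaller free fraction and higher numbers for a larger free fraction), compound 2 gives 0.000975, the higher of the two numbers measured so far; compound 1 gives 0.00023, a gap that lies beyond the usual scatter of this assay. Among the compounds with values here, the two measured compounds differ in several places at once, so no single structural step between them can be read from their values.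

Compound 3 `CCCCN(c1nc2c(C(=O)O)cccc2o1)[C@H](C)c1ccc(-c2ccccc2-c2nnn[nH]2)cc1` has not yet been measured. It differs from compound 2 in one place: hydroxy in place of methylamino on a carbonyl carbon.

Expectation for compound 3. Within the data shown here, compound 1, the only measured compound that carries a carboxy, gives 0.00023, below compound 2, but the other differences between compound 1 and compound 2 leave that comparison open. For compound 3 a downward step from compound 2 in this assay is expected, of a size around a 2.4-fold lower number from compound 2 to compound 3 (0.39 log units; beyond the scatter), though the step could also fall within the scatter. The unbound fraction of compound 3 in this assay is thus estimated at 0.0004, with a range from 0.00015 to 0.0011.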

Compound 3, unbound fraction: 0.000285
Compound 3: the middle estimate sits 1.4-fold (0.15 log units) above what was measured; the range from low to high includes it.
By their numbers in this assay, from the lowest: compounds 1 and 3 (each within the scatter of the next); then compound 2.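

In this assay, going by these compounds alone, the change from methylcarbamoyl to carboxy gives the first step that can be read at a single place, a 3.4-fold lower number from compound 2 to compound 3 (0.53 log units; beyond the scatter), and it shows that the group on this carbonyl carbon makes a difference beyond the scatter to the unbound fraction while the rest of the structure stays fixed. The direction is the one that goes with hydroxy in place of methylamino, but it rests on this single pair and holds only for this change on this structure. No measured property of these compounds bears on the step, so the data give no account of why the number moves.

A primary amide, a methyl ester or a longer chain on the amide nitrogen in the same place would show whether the unbound fraction tracks the carboxy alone or varies across other groups on this carbonyl carbon. A methylcarbamoyl on the core of compound 1 would show whether the step from methylcarbamoyl to carboxy carries over to a different structure, which the present pair leaves open.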